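Allyl chain at the saturated ring carbon of compound 2

The source may hold more compounds than are shown below. What is called first, only, known or untested is meant among the compounds shown, and "the series" means these compounds.

Measured compounds in a functional assay on LNCaP cells (Homo sapiens) for antiproliferative activity; a lower number here means a stronger inhibitor, a higher number a weaker inhibitor:
- compound 1 `Cn1ncc(Cl)c1-c1cc(C(=O)N[C@@H]2CN[C@H](CCNS(C)(=O)=O)C[C@H]2c2ccc(F)c(F)c2)oc1Cl`: 50 nM
- compound 2 `Cn1ncc(Cl)c1-c1cc(C(=O)N[C@@H]2CN[C@H](CCN3CCC(O)CC3)C[C@H]2c2ccc(Cl)c(Cl)c2)oc1Cl`: 1140 nM
- compound 3 `Cn1ncc(Cl)c1-c1cc(C(=O)N[C@@H]2CN[C@H](CCn3cncn3)C[C@H]2c2ccc(Cl)c(Cl)c2)oc1Cl`: 60 nM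

Compound 2 gives the highest number of the three in this assay; compound 3 sits nearest, compound 1 furthest, both well beyond the scatter.

Compound 4 `C=CC[C@@H]1C[C@@H](c2ccc(Cl)c(Cl)c2)[C@H](NC(=O)c2cc(-c3c(Cl)cnn3C)c(Cl)o2)CN1` is not yet measured. Its change from compound 2 is vinyl in place of (4-hydroxypiperidin-1-yl)methyl on a saturated chain carbon bound to a saturated ring carbon.

Going by the values given here, the one step that bears on it is a 19-fold lower number from compound 2 to compound 3 (1.28 log units; beyond the scatter), where the 4-hydroxypiperidin-1-yl group leaves the same chain and a ring of another kind enters. Compound 4 removes the same group but puts nothing with a donor or acceptor in its place, so that step is only a partial guide. Among the compounds with values here, compound 1, with its methanesulfonamide chain on a different aryl group, gives no comparable step.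

A lower number than compound 2 is expected for compound 4, but with less confidence than the measured step would suggest: the estimate is 250 nM, between 70 nM and 900 nM, meaning a step of a 4.6-fold lower number from compound 2 to compound 4 (0.66 log units; beyond the scatter).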

Compound 4, half-maximal inhibitory concentration: 160 nM
Estimate against measurement, compound 4: 1.6-fold (0.19 log units) above, within the range that was stated.
By their numbers in this assay, from the lowest: compounds 1 and 3 (each within the scatter of the next); then compound 4; then compound 2.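

In this assay, a 7.1-fold lower number from compound 2 to compound 4 (0.85 log units; beyond the scatter) shows that this position tolerates a chain without a ring or any hydrogen-bond donor or acceptor, and that losing (4-hydroxypiperidin-1-yl)methyl lowers the number even when only vinyl enters. The entering group also matters: a 2.7-fold higher number from compound 3 to compound 4 (0.43 log units; beyond the scatter), so vinyl does not match (1H-1,2,4-triazol-1-yl)methyl, and removing the hydroxypiperidine alone does not reach the level of compound 3. No measurement at hand gives a reason for either step.

Still open, going by these compounds, is whether the double bond of compound 4 contributes at all, which a saturated propyl chain at the same place would test. Also open, on these data alone, is how a simple amine or a carboxylic acid at the end of the chain would compare with the triazole of compound 3.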